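Ethoxy on the Anilino Ring of a Quinone Core

The compounds below may be only part of what the source reports. "The series", "measured", "known", "first", "only" and "open" are said of these compounds alone.

Of the compounds shown here, two have been tested so far. Compound 1 `O=C1C(Nc2ccccc2)=CC(=O)c2c1nc1n2[C@H]2OC[C@@H](O)[C@H]2OC1` gives 1830 nM in a functional assay on MGC-803 cells (Homo sapiens) for inhibition, read by sulforhodamine B assay; on this read-out higher numbers stand for weaker inhibition and lower numbers for stronger inhibition; it stands at the upper end of the two numbers in hand, though its neighbour lies within the usual scatter of it. Compound 2 `O=C1C=C(Nc2ccccc2)C(=O)c2c1nc1n2[C@H]2OC[C@@H](O)[C@H]2OC1` gives 1730 nM in this assay, so the two values show no difference that can be read. Compound 3 `CCOc1ccccc1NC1=CC(=O)c2c(nc3n2[C@H]2OC[C@@H](O)[C@H]2OC3)C1=O` has not yet been measured. It differs from compound 1 in one place: ethoxy in place of hydrogen on an aromatic carbon. Within the data shown here, no step between measured compounds bears on this change, so the expectation rests on compound 1 alone. From the value of compound 1 of 1830 nM the author expects a step of a 1.2-fold lower number from compound 1 to compound 3 (0.09 log units; within the scatter), that is, no change clearly beyond the scatter. Compound 3 is therefore estimated at 1500 nM, with a range from 500 nM to 4500 nM.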

Compound 3, half-maximal inhibitory concentration: 2830 nM
Compound 3: middle estimate off by 1.9-fold (0.28 log units), on the low side, within the range that was stated.
By their numbers in this assay, from the lowest: compounds 2, 1 and 3 (each within the scatter of the next).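

Compound 3 carries ethoxy on an aromatic carbon of the six-membered aromatic ring, ortho to a large group, and in this assay this gives a 1.5-fold higher number from compound 1 to compound 3 (0.19 log units; within the scatter). The step lies within the scatter, so this carbon of the anilino ring accepts ethoxy without a readable change, something the earlier pair of compounds could not show, as neither carries any group on that ring. No data in hand offer an explanation for this result.

The compounds shown leave open whether an amine or a carboxylic acid on this same carbon, or an alkoxy chain longer than ethoxy such as butoxy, would move the number beyond the scatter. They also leave open whether ethoxy on another carbon of this ring would read the same.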